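Swapping Methyl for Methoxy on an Aromatic Carbon

The source may hold more compounds than are shown below. What is called first, only, known or untested is meant among the compounds shown, and "the series" means these compounds.

Compound 1 `CC(Oc1ccc(Cl)cc1Cl)C(=O)NCc1ccccc1`: 95000 nM
Compound 2 `CC(Oc1ccc(Cl)cc1Cl)C(=O)NCc1cccc(Cl)c1`: 19000 nM
Compound 3 `Cc1cccc(CNC(=O)C(C)Oc2ccc(Cl)cc2Cl)c1`: 45000 nM

These three values come from an ADME assay on CHO cells (Cricetulus griseus) for cytotoxicity, read by LDH release; on this read-out higher numbers stand for weaker inhibition and lower numbers for stronger inhibition. Compound 3 sits in the middle, with the second highest of the three numbers. Within the data shown here, the next compound to be tested, compound 4 `COc1cccc(CNC(=O)C(C)Oc2ccc(Cl)cc2Cl)c1`, has no measurement yet. It carries methoxy in place of methyl on an aromatic carbon.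

Among the measured compounds shown here, no measured step makes this exact swap, so the evidence is indirect. Putting chloro in place of hydrogen gave a 5.0-fold lower number from compound 1 to compound 2 (0.70 log units; beyond the scatter). Putting methyl in place of hydrogen gave a 2.1-fold lower number from compound 1 to compound 3 (0.32 log units; beyond the scatter). Both steps are modest, though beyond the usual scatter. For the measured compounds named here, the closest parallel is the one step that replaces one group with another, methyl in place of chloro, which gave a 2.4-fold higher number from compound 2 to compound 3 (0.37 log units; beyond the scatter). Among these three compounds, then, single changes have moved the number only modestly in this assay. Going by the values given here, nothing measured so far points to a direction for methoxy, so no step beyond the scatter is the best guess. The expected change is a 1.1-fold higher number from compound 3 to compound 4 (0.05 log units; within the scatter). Compound 4 is estimated at 50000 nM, with an expected range from 20000 nM to 110000 nM.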

Compound 4, half-maximal inhibitory concentration: > 100000 nM
Compound 4: only a limit was reported (the forecaster's own chance of this, stated with the estimate: 10%); middle value at least 2.0-fold (0.30 log units) from the limit.
By their numbers in this assay, from the lowest: compound 2; then compound 3; then compound 1. At a limit, above all of these: compound 4.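

In this assay, compound 4 gives only a limit, not a number: the limit of > 100000 nM in this assay, at which 1 of the 4 values shown sits. On this aromatic carbon, chloro and methyl each gave a lower number than the hydrogen of compound 1, but methoxy breaks that pattern, with an at least 2.2-fold higher number from compound 3 to compound 4 (0.34 log units; beyond the scatter) and an at least 5.2-fold higher number from compound 2 to compound 4 (0.72 log units; beyond the scatter), so the position does not respond to every added group in the same direction. Against hydrogen itself, the result is an at least 1.0-fold higher number from compound 1 to compound 4 (0.02 log units; that floor lies within the scatter), so compound 4 cannot be said to differ from compound 1, and this swap of methyl for methoxy, which adds one oxygen and one hydrogen-bond acceptor, mainly shows that a small change here can undo the drop in the number that methyl gave.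

How far the true value of compound 4 lies past its limit stays unknown, so all three steps are floors rather than sizes, and nothing shown separates the oxygen from the extra size of methoxy as the reason for the change. An ethyl group, a hydroxyl or an amine on the same aromatic carbon would be needed to tell these apart.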